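Adding a chloro to the benzyl arm of compound 2

This account rests on a few compounds, and the source may have more. Where it says the series, first, only, none or still open, it means among the compounds named here.

Measured compounds:
- compound 1, `Clc1ccc(CO/N=C/c2c(-c3cccc4ccccc34)nc3sccn23)cc1Cl`, in an assay on HepG2 cells for agonist activity at nuclear receptor subfamily 1 group I member 3 (Homo sapiens), read by a luciferase reporter, with a stated time of 23 h (a higher number here means that more compound is needed for the effect, a lower number that less compound is needed), compound 1 gives 940 nM.
- compound 2, `C(=N/OCc1ccccc1)\c1c(-c2ccc3ccccc3c2)nc2occn12`, in this assay compound 2 gives 840 nM.
- compound 3, `FC(F)(F)c1ccc(-c2nc3sccn3c2/C=N/OCc2ccc(Cl)c(Cl)c2)cc1`, in this assay compound 3 gives 880 nM.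

All three numbers sit within the usual scatter of one another, so compound 2 cannot be called more or less potent than compound 1 or compound 3; it simply shows the numerically lowest value of a tight group. Within the data shown here, the one step between compounds that differ in a single place, a 1.1-fold lower number from compound 1 to compound 3 (0.03 log units; within the scatter), concerns the aryl group on the shared core and says nothing about the benzyl arm.

Compound 4, `Clc1ccc(CO/N=C/c2c(-c3ccc4ccccc4c3)nc3occn23)cc1`, differs from compound 2 by chloro in place of hydrogen on an aromatic carbon. Among the measured compounds shown here, no measured step isolates this change. The only related hint is that compound 1 and compound 3, which carry a dichloro-substituted benzyl arm on a different core and aryl group, give values close to that of compound 2. With nothing pointing either way, compound 4 is expected to show no step beyond the scatter, a 1.0-fold higher number from compound 2 to compound 4 (0.01 log units; within the scatter). The estimated value for compound 4 is 850 nM, with a range from 400 nM to 1800 nM.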

Compound 4, half-maximal effective concentration: 990 nM
Estimate against measurement, compound 4: 1.2-fold (0.07 log units) below; the range from low to high includes it.
By their numbers in this assay, from the lowest: compounds 2, 3, 1 and 4 (each within the scatter of the next).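

This is the first step shown that isolates a change on the benzyl arm: in this assay, chloro in place of hydrogen, on the aromatic carbon para to a large group, gives a 1.2-fold higher number from compound 2 to compound 4 (0.07 log units; within the scatter). The phenyl of compound 2 and the 4-chlorophenyl of compound 4 therefore cannot be told apart by this read-out, and this position carries one added chlorine atom without a step beyond the scatter. No supporting measurement bears on why the result came out this way.

Still open, going by these compounds, is whether a different group at this position, such as a methoxy, an amine or a carboxylic acid, would also stay within the scatter. Also open, on these data alone, is whether chloro would behave the same way on the core and aryl group of compound 1 or compound 3.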